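Ester chain length in a malonamide series

This account rests on a few compounds, and the source may have more. Where it says the series, first, only, none or still open, it means among the compounds named here.

Measured so far:
compound 1, `CCCCCCCCCCC(C)OC(=O)CC(=O)Nc1c(C(C)C)cccc1C(C)C`: 6 nM
compound 2, `CCCCCC(C)OC(=O)CC(=O)Nc1c(C(C)C)cccc1C(C)C`: 27 nM

Both compounds share the same anilide core and differ only in the length of the ester chain. In an assay on microsomes from intestine for inhibition of acyl-CoA:cholesterol acyltransferase (Oryctolagus cuniculus) (a lower number here means a stronger inhibitor, a higher number a weaker inhibitor), compound 2 gives 27 nM, the higher of the two numbers; compound 1 gives 6 nM. For the measured compounds named here, the single measured step, a 4.5-fold higher number from compound 1 to compound 2 (0.65 log units; beyond the scatter), shows that shortening the chain raises the number.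

Compound 3, `CCCCCCCCCCCCCCC(C)OC(=O)CC(=O)Nc1c(C(C)C)cccc1C(C)C`, is not yet measured. Relative to compound 2 the change is nonyl in place of hydrogen on a saturated chain carbon, six bonds along the chain from an oxygen next to a carbonyl group, which extends the chain past the length found in compound 1. Going by the values given here, only the step from compound 1 to compound 2 bears on this, and it ran in the opposite direction, so a lower number is expected for compound 3, of a size around a 5.4-fold lower number from compound 2 to compound 3 (0.73 log units; beyond the scatter) in this assay. Whether a chain longer than that of compound 1 gives any further gain cannot be told from two points. The estimate for compound 3 in this assay is 5 nM, with a range of 2 nM to 20 nM.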

Compound 3, half-maximal inhibitory concentration: 11 nM
Compound 3: the middle estimate sits 2.2-fold (0.34 log units) below what was measured; low and high end bracket the measured number.
By their numbers in this assay, from the lowest: compounds 1 and 3 (each within the scatter of the next); then compound 2.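

In this assay the nonyl change still lowers the number against the shorter chain of compound 2, with a 2.5-fold lower number from compound 2 to compound 3 (0.39 log units; beyond the scatter) in the direction expected from the earlier step. The new information is that extension past the chain of compound 1 brings no readable gain: a 1.8-fold higher number from compound 1 to compound 3 (0.26 log units; within the scatter) is the result of butyl in place of hydrogen on a saturated chain carbon. No data here bear on what lies behind these numbers.

Still open, going by these compounds, is whether a longer chain than that of compound 3 would stay within the scatter of compound 3 or move away from it. Also open, on these data alone, is how this position would respond to an amine or a carboxylic acid carried on the chain.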